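The compounds below may be only part of what the source reports. "The series", "measured", "known", "first", "only" and "open" are said of these compounds alone.

Measured so far in an assay on CHO cells for displacement of a labelled ligand from 5-hydroxytryptamine receptor 1D (Homo sapiens); on this read-out lower numbers stand for stronger inhibition and higher numbers for weaker inhibition: compound 1 `COC[C@H](NC1CCN(CCCc2c[nH]c3ccc(Cn4cncn4)cc23)CC1)c1ccc(F)cc1` gives 5 nM; compound 2 `CN(Cc1ccccc1)CC1CCN(CCCc2c[nH]c3ccc(-n4cnnc4)cc23)CC1` gives 0.9 nM; compound 3 `CN(Cc1ccc(S(C)(=O)=O)cc1)C1CCN(CCCc2c[nH]c3ccc(-n4cnnc4)cc23)CC1` gives 18 nM.

Of these three, compound 2 carries the lowest number and so the strongest inhibition; both compound 1 and compound 3 lie beyond the usual scatter above it, with compound 3 the furthest away. Compound 4 `C[C@@H](NCC1CCN(CCCc2c[nH]c3ccc(-n4cnnc4)cc23)CC1)c1ccccc1` has not yet been measured in this assay. It holds the same atoms as compound 2, joined differently: (1-phenylethyl)amino in place of benzyl(methyl)amino on a saturated chain carbon bound to a saturated ring carbon. Within the data shown here, no measured pair here isolates such a change, so no measured step shows its size. The step from compound 2 to compound 4 is expected to be a 2.2-fold higher number from compound 2 to compound 4 (0.35 log units; beyond the scatter), a modest weakening that may stay within the scatter. Compound 4 is estimated at 2 nM, in the range 0.5 nM to 8 nM.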

Compound 4, half-maximal inhibitory concentration: 1.4 nM
The estimate for compound 4 lay 1.4-fold (0.15 log units) above the measured number; measured number inside the range.
By their numbers in this assay, from the lowest: compounds 2 and 4 (each within the scatter of the next); then compound 1; then compound 3.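

In this assay, among these compounds, putting (1-phenylethyl)amino in place of benzyl(methyl)amino on a saturated chain carbon bound to a saturated ring carbon gives a 1.6-fold higher number from compound 2 to compound 4 (0.19 log units; within the scatter) as the first single-place step. This position therefore accepts the rearranged atoms, with their added hydrogen-bond donor and defined stereocentre, without a change distinguishable from assay scatter. No supporting data explain this result.

Going by these compounds, whether the mirror-image form of (1-phenylethyl)amino would behave the same remains open. So does the outcome for a larger (1-phenylpropyl)amino group at this place.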